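Trimming a Fatty Chain Further in Search of Potency

The compounds below may be only part of what the source reports. "The series", "measured", "known", "first", "only" and "open" are said of these compounds alone.

Measured in a functional assay on CHO cells (Cricetulus griseus) for inhibition; on this read-out higher numbers stand for weaker inhibition and lower numbers for stronger inhibition:
- Compound 1 `CCCCCCCCCCCCCCCC(=O)N[C@@H](CO)C[C@@H](O)c1ccccc1`: > 1000 nM, a limit
- Compound 2 `CCCCCCCCCCCCCCC(=O)N[C@@H](CO)C[C@@H](O)c1ccccc1`: 90 nM
- Compound 3 `CCCCCCCCCCCCCCCCC(=O)N[C@@H](CO)C[C@@H](O)c1ccccc1`: > 1000 nM, a limit

Compound 4 `CCCCCCCCCCCCC(=O)N[C@@H](CO)C[C@@H](O)c1ccccc1` has not been measured.

Compound 3 gives > 1000 nM, which is a limit and not a true number. It therefore stands at the limit of > 1000 nM in this assay, at which 2 of the 3 values shown sit. The change to compound 4 is hydrogen in place of butyl on a saturated chain carbon, ten or more bonds along the chain from a carbonyl carbon.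

Three measured steps alter the same kind of chain carbon. Removing methyl gives an at least 11-fold lower number from compound 1 to compound 2 (1.04 log units; beyond the scatter), and adding ethyl gives an at least 11-fold higher number from compound 2 to compound 3 (1.04 log units; beyond the scatter). Both are large, and both link less chain to a lower number. The third, a step that the two limits leave unreadable from compound 1 to compound 3, adds nothing.

Butyl is a larger loss than either of those changes, and no measured compound shows what happens past compound 2, so the trend may not hold. A clear drop in the number is still expected, and the estimated change is an at least 5.0-fold lower number from compound 3 to compound 4 (0.69 log units; beyond the scatter). For compound 4 the estimated value is 200 nM, with an expected range of 30 nM to 1000 nM.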

Compound 4, half-maximal inhibitory concentration: 50 nM
Compound 4: middle estimate off by 4.0-fold (0.60 log units), on the high side, and the stated range covers the measured number.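

Going shorter than compound 2 does not bring back the weak inhibition, and the two shorter chains cannot be told apart: a 1.8-fold lower number from compound 2 to compound 4 (0.26 log units; within the scatter). The other two steps are large, an at least 20-fold lower number from compound 3 to compound 4 (1.30 log units; beyond the scatter) and an at least 20-fold lower number from compound 1 to compound 4 (1.30 log units; beyond the scatter), so among these four compounds the read-out looks less like a steady slope than a sharp edge, with both shorter chains on the strong side and both longer chains on the weak side. Both large steps start from a limit and not from a true number: the limit of > 1000 nM in this assay, at which 2 of the 4 values shown sit.

Still open, on these data alone, is whether a chain shorter than that of compound 4 holds this level, or where inhibition finally falls away. Also open, as far as these compounds go, is how an amine or a carboxylic acid on this saturated chain carbon would read out.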